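This account rests on a few compounds, and the source may have more. Where it says the series, first, only, none or still open, it means among the compounds named here.

Compound 1 `Cc1cnc(-c2ccccc2C(C)C)nc1NCc1ccc(-c2cccnc2)cc1` gives 70 nM in an assay on a protein complex for inhibition of ubiquitin carboxyl-terminal hydrolase 1/WD repeat-containing protein 48 (Homo sapiens), read by fluorescence; on this read-out lower numbers stand for stronger inhibition and higher numbers for weaker inhibition. Compound 2 `COc1cnc(-c2ccccc2C(C)C)nc1NCc1ccc(-c2cccnc2)cc1` gives 70 nM in this assay.

On these numbers compound 2 stands level with compound 1: the step of no change at the digits printed from compound 1 to compound 2 (within the scatter) shows no change beyond the scatter. Compound 3 `CC(C)c1ccccc1-c1ncc(F)c(NCc2ccc(-c3cccnc3)cc2)n1` differs from compound 2 by fluoro in place of methoxy on an aromatic carbon. Going by the values given here, the one measured step that bears on this place is no change at the digits printed from compound 1 to compound 2 (within the scatter), in which one small group replaced another there without any shift. A further exchange of a small group at the same place is therefore expected to leave this assay much where it stands, the expected step being no change at the digits printed from compound 2 to compound 3 (within the scatter). Compound 3 is estimated at 70 nM, within 30 nM to 160 nM.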

Compound 3, half-maximal inhibitory concentration: 110 nM
Beside the measured number, compound 3's estimate is 1.6-fold (0.20 log units) below it, and the stated range covers the measured number.
By their numbers in this assay, from the lowest: compounds 1, 2 and 3 (each within the scatter of the next).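

In this assay the exchange of methoxy for fluoro gives a 1.6-fold higher number from compound 2 to compound 3 (0.20 log units; within the scatter) and the exchange of methyl for fluoro gives a 1.6-fold higher number from compound 1 to compound 3 (0.20 log units; within the scatter), so a third small group at this place leaves the read-out within the scatter. Losing the oxygen of methoxy, with its hydrogen-bond acceptor, therefore shifts nothing beyond the scatter here. Nothing shown explains why these three groups are interchangeable at this place.

Going by these compounds, what an amine, a carboxylic acid or a longer alkyl chain would do at this place stays open. On these data alone, whether plain hydrogen there would hold the read-out also stays open.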